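The source may hold more compounds than are shown below. What is called first, only, known or untested is meant among the compounds shown, and "the series" means these compounds.

Measured in an ADME assay on microsomes from liver (Homo sapiens) for metabolic stability; on this read-out lower numbers stand for slow clearance and higher numbers for fast clearance:
- compound 1 `C[C@H](NC(=O)Cn1nnc2ccccc2c1=O)c1ccc(Cl)cc1`: < 9.9 mL/min/kg (a limit)
- compound 2 `COc1ccc([C@H](C)NC(=O)Cn2nnc3ccccc3c2=O)cc1`: 13 mL/min/kg
- compound 3 `Cc1ccc([C@H](C)NC(=O)Cn2nnc3ccccc3c2=O)nc1`: < 9.9 mL/min/kg (a limit)

Compound 3 is reported only as a limit, < 9.9 mL/min/kg, and not as a number. Its place in the series is the limit of < 9.9 mL/min/kg in this assay, at which 2 of the 3 values shown sit. Compound 2 is the only one of the three with a number.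

The next analogue is compound 4 `C[C@H](NC(=O)Cn1nnc2ccccc2c1=O)c1ccc(C(F)(F)F)cn1`, in which trifluoromethyl replaces methyl on an aromatic carbon: trifluoromethyl in place of methyl on an aromatic carbon.

For the measured compounds named here, no measured step makes this exchange, so the evidence is indirect. The step with methoxy in place of chloro is an at least 1.3-fold higher number from compound 1 to compound 2 (0.11 log units; that floor lies within the scatter). The step with 5-methylpyridin-2-yl in place of 4-methoxyphenyl is an at least 1.3-fold lower number from compound 2 to compound 3 (0.11 log units; that floor lies within the scatter). Neither floor goes beyond the scatter. The remaining step, a step that the two limits leave unreadable from compound 1 to compound 3, gives no size.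

With only these small or unreadable steps available, no step beyond the scatter is expected in this assay, and no direction can be assigned. The expected step is a step that the limit leaves unreadable from compound 3 to compound 4. A second report as a limit is the likelier outcome. Compound 4 is estimated at 9 mL/min/kg, with an expected range from 6 mL/min/kg to 15 mL/min/kg.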

Compound 4, clearance: < 9.9 mL/min/kg
Compound 4 was reported as a limit; the forecaster's own chance of this, stated with the estimate: 65%; the middle value is on the limit's open side.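

Compound 3 and compound 4 are both reported only as limits in this assay, so the step between them cannot be read, and trifluoromethyl in place of methyl shows neither size nor direction. The compounds shown leave open how the true clearances of compound 1, compound 3 and compound 4 compare, with the series standing at: the limit of < 9.9 mL/min/kg in this assay, at which 3 of the 4 values shown sit.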